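From pyrrolidin-1-yl to piperidin-1-yl on a sulfonyl sulfur

The source may report more compounds than this note shows. Statements on the series, on what has been measured and on what is new or still open speak of the compounds shown alone.

Compounds measured so far in a toxicity assay on Vero cells (Chlorocebus sabaeus) for cytotoxicity, read by MTT assay; a higher number here means a weaker inhibitor, a lower number a stronger inhibitor

compound 1 `O=C(Nc1sccc1C(=O)Nc1ccccn1)c1ccc(S(=O)(=O)N2CCCCC2)cc1` gives "nd" (no result reported)
compound 2 `Cc1ccnc(NC(=O)c2ccsc2NC(=O)c2ccc(S(=O)(=O)N3CCCCC3)cc2)n1` gives 32.8 ug/mL
compound 3 `CCOC(=O)NC(=O)c1ccsc1NC(=O)c1ccc(S(=O)(=O)N2CCCC2)cc1` gives 58.2 ug/mL

Compound 3 stands level with compound 2 within the usual scatter, so these two numbers show no order. No number was reported for compound 1. Compound 4 `CCOC(=O)NC(=O)c1ccsc1NC(=O)c1ccc(S(=O)(=O)N2CCCCC2)cc1` has not yet been measured. It differs from compound 3 in one place, with piperidin-1-yl in place of pyrrolidin-1-yl on a sulfonyl sulfur.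

For the measured compounds named here, no pair of measured compounds shows this change on its own, so the expectation rests on thin evidence. Compound 2 also carries piperidin-1-yl on a sulfonyl sulfur and gives 32.8 ug/mL in this assay, although it differs elsewhere too. No shift beyond the scatter is therefore expected, and the estimated step is small (a 1.2-fold lower number from compound 3 to compound 4 (0.08 log units; within the scatter)). The estimated value for compound 4 is 48 ug/mL (expected range 24 ug/mL to 95 ug/mL).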

Compound 4, half-maximal inhibitory concentration: 18.6 ug/mL
Beside the measured number, compound 4's estimate is 2.6-fold (0.41 log units) above it; the measured number lies below the stated range.
By their numbers in this assay, from the lowest: compounds 4, 2 and 3 (each within the scatter of the next, the first and the last beyond it).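

In this assay, for the compounds shown here, the change on the sulfonyl sulfur from pyrrolidin-1-yl to piperidin-1-yl gives a 3.1-fold lower number from compound 3 to compound 4 (0.50 log units; beyond the scatter) and so provides the first direct reading of this change, showing that the position responds to it. With piperidin-1-yl held in place, ethoxycarbonyl in place of 4-methylpyrimidin-2-yl on an amide-type nitrogen gives a 1.8-fold lower number from compound 2 to compound 4 (0.25 log units; within the scatter) and so shows no shift that can be told from the scatter. Nothing available here accounts for the lower number that comes with the six-membered ring.

From the compounds shown here alone, whether the trend extends to other groups on the sulfonyl sulfur, such as morpholin-4-yl or dimethylamino, remains open. Going by these compounds, it is also open whether the same ring change would give a similar step with 4-methylpyrimidin-2-yl on the amide-type nitrogen, the group carried by compound 2.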